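From methoxy to phenyl: how large a step?

This account rests on a few compounds, and the source may have more. Where it says the series, first, only, none or still open, it means among the compounds named here.

Measured so far in a functional assay on B16-F10 cells (Mus musculus) for antiproliferative activity, read by MTT assay, with a stated time of 48 h; a higher number here means a weaker inhibitor, a lower number a stronger inhibitor
Compound 1 `COc1ccc(/C=C/c2cc(OC)cc(OC)c2/C=C/C(=O)c2ccc(C(F)(F)F)cc2)cc1` gives 4.3 ug/mL
Compound 2 `COc1ccc(/C=C/c2cc(OC)cc(OC)c2/C=C/C(=O)c2ccccc2C)cc1` gives 6.1 ug/mL
Compound 3 `COc1ccc(/C=C/c2cc(OC)cc(OC)c2/C=C/C(=O)c2ccc(OC)cc2)cc1` gives 5.8 ug/mL

Compound 3 has no separate rank, with a 1.1-fold lower number from compound 2 to compound 3 (0.02 log units; within the scatter) and a 1.3-fold higher number from compound 1 to compound 3 (0.13 log units; within the scatter) as its gaps to the other two. Compound 4 `COc1ccc(/C=C/c2cc(OC)cc(OC)c2/C=C/C(=O)c2ccc(-c3ccccc3)cc2)cc1` differs from compound 3 by one swap, phenyl in place of methoxy on an aromatic carbon. All measured steps changed the ring on the carbonyl carbon, and the third of them is a 1.4-fold higher number from compound 1 to compound 2 (0.15 log units; within the scatter) as well. For the measured compounds named here, no measured compound carries phenyl there, so these steps guide only loosely. In this assay the estimated step is a 1.2-fold lower number from compound 3 to compound 4 (0.06 log units; within the scatter) and nothing beyond the scatter is expected. Compound 4 is expected at 5 ug/mL (estimated range 2.5 ug/mL to 10 ug/mL).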

Compound 4, half-maximal inhibitory concentration: 10.6 ug/mL
For compound 4 the middle estimate is 2.1-fold (0.33 log units) below the measured one, outside the stated range (above it).
By their numbers in this assay, from the lowest: compounds 1, 3, 2 and 4 (each within the scatter of the next, the first and the last beyond it).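

In this assay, for the compounds shown here, a phenyl at this position produces the only step beyond the scatter so far, a 2.5-fold higher number from compound 1 to compound 4 (0.39 log units; beyond the scatter), with phenyl replacing trifluoromethyl. The other two steps stay within the scatter: a 1.8-fold higher number from compound 3 to compound 4 (0.26 log units; within the scatter), with phenyl replacing methoxy, and a 1.7-fold higher number from compound 2 to compound 4 (0.24 log units; within the scatter), with 4-phenylphenyl replacing 2-methylphenyl. This position therefore accepts a whole extra ring with only a modest change in the number.

Nothing measured here explains that modest step. From the compounds shown here alone, it also remains open how an amine, a carboxylic acid or a longer chain at this position would read in this assay.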